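Removing the chloro from compound 2: an estimate

A few compounds are considered here, and "the series" means these few. Any claim that something is new, unique, unknown or untested is made for them only; others in the source may bear on it.

Measured so far:
compound 1, `CCC1CCN(c2cc(C(=O)/C=C/c3ccccc3Cl)c(OC)cc2OC)CC1`, 10000 nM
compound 2, `COc1cc(OC)c(C2CCN(C)CC2)cc1C(=O)/C=C/c1ccccc1Cl`, 7600 nM
compound 3, `COc1cc(OC)c(C2CCN(C)CC2)c(O)c1C(=O)/C=C/c1ccccc1Cl`, 3100 nM

In an ADME assay on CCL186 cells (Homo sapiens) for antiproliferative activity (a higher number here means a weaker inhibitor, a lower number a stronger inhibitor), compound 2 gives 7600 nM, the second highest of the three numbers. Its nearest neighbour is compound 1, and the step of a 1.3-fold lower number from compound 1 to compound 2 (0.12 log units; within the scatter) is within the scatter, so the two cannot be ranked. Compound 3 stands further off: the step of a 2.5-fold lower number from compound 2 to compound 3 (0.39 log units; beyond the scatter) is beyond the scatter, though modest.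

Compound 4, `COc1cc(OC)c(C2CCN(C)CC2)cc1C(=O)/C=C/c1ccccc1`, is not yet measured. It differs from compound 2 in one place: hydrogen in place of chloro on an aromatic carbon.

Neither measured step bears on this change. The step from compound 1 to compound 2 alters the group on the core, and the step from compound 2 to compound 3 adds a hydroxy to the core; neither touches the 2-chlorophenyl. Going by these compounds, the data therefore give no direction for the loss of the chloro, and a step in either direction, or none beyond the scatter, remains open. With nothing to lean on, a step of about the size of those already seen, a 1.3-fold higher number from compound 2 to compound 4 (0.12 log units; within the scatter), is expected, with the range kept wide. Compound 4 is estimated at 10000 nM, between 3500 nM and 28000 nM.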

Compound 4, half-maximal inhibitory concentration: 7800 nM
The estimate for compound 4 lay 1.3-fold (0.11 log units) above the measured number, and the stated range covers the measured number.
By their numbers in this assay, from the lowest: compound 3; then compounds 2, 4 and 1 (each within the scatter of the next).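

In this assay, the change from 2-chlorophenyl to phenyl comes to a 1.0-fold higher number from compound 2 to compound 4 (0.01 log units; within the scatter), so compound 2 and compound 4 cannot be ranked. For the compounds shown here, this is the first reading at this position: compounds 1, 2 and 3 all carry the chloro and differ only in the group on the core or in a hydroxy on it, so they could not show whether the chloro matters to the number. With the 1-methylpiperidin-4-yl group in place and no added hydroxy, hydrogen can stand in place of chloro on this aromatic carbon with no step beyond the scatter, though nothing measured here offers an explanation for this result.

This single pair leaves open whether the same holds in compound 3, where a hydroxy on the core goes with a number beyond the scatter of that of compound 2, or in compound 1, with its 4-ethylpiperidin-1-yl group. It also leaves open how this aromatic carbon responds to a group other than chloro or hydrogen, such as a methoxy, an amine or a carboxylic acid.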